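The source may report more compounds than this note shows. Statements on the series, on what has been measured and on what is new or still open speak of the compounds shown alone.

For the measured compounds named here, compound 2 `Clc1ccc(-c2csc(N/N=C/c3ccc(Cl)cc3Cl)n2)cc1` stands lowest of the two numbers measured so far in a functional assay, read by spectrophotometry, with a stated time of 15 min, tested at 60 ug/mL (a lower number here means a weaker effect, a higher number a stronger effect of the compound at the concentration tested), where compound 2 gives 80.4%. Its nearest neighbour is compound 1 `Cc1ccc(-c2csc(N/N=C/c3ccc(Cl)cc3Cl)n2)cc1`, for which this assay gives 83.2%, the two values being separated by a number 2.8 percentage points lower from compound 1 to compound 2 (within the scatter). Compound 3 `Clc1ccc(/C=N/Nc2nc(-c3ccccc3)cs2)c(Cl)c1` is still to be measured in this assay. It differs from compound 2 by hydrogen in place of chloro on an aromatic carbon. Going by the values given here, only one measured step touches this place on the ring, the exchange of methyl for chloro, which moved this assay by a number 2.8 percentage points lower from compound 1 to compound 2 (within the scatter) and so stayed within the scatter. Among the compounds with values here, no measured step removes the group altogether, so the data give no direction for such a change. For compound 3 a step no larger than the scatter is therefore expected, a number 2.4 percentage points lower from compound 2 to compound 3 (within the scatter). Compound 3 is estimated to give 78% in this assay, within a range from 64% to 90%.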

Compound 3, a percentage reported as inhibition, at one concentration (the size of the read-out at that concentration, not a potency): 80.4%
For compound 3 the middle estimate is 2.4 percentage points below the measured one; measured number inside the range.
By their numbers in this assay, from the lowest: compounds 2, 3 and 1 (each within the scatter of the next).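

In this assay, removing the group altogether, the change from 4-chlorophenyl to phenyl, gives a step within the scatter (no change at the digits printed from compound 2 to compound 3 (within the scatter)), and hydrogen in place of methyl at the same place does likewise (a number 2.8 percentage points lower from compound 1 to compound 3 (within the scatter)). For the compounds shown here, the earlier compounds showed only one group exchanged for another, whereas these steps show that, among chloro, methyl and hydrogen, the read-out at this single concentration does not depend on a group being present at this place on the ring. Nothing at hand bears on why these three compounds read alike. As far as these compounds go, it remains open whether an amine, a carboxylic acid or a longer chain at this place would leave the read-out as it stands. From the compounds shown here alone, since the read-out comes from one concentration, whether these three compounds would also read alike at other concentrations remains open.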